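Notes on nitro in place of fluoro in this series

The compounds below may be only part of what the source reports. "The series", "measured", "known", "first", "only" and "open" are said of these compounds alone.

In a functional assay on Caco-2 cells (Homo sapiens) for cytotoxicity, with a stated time of 48 h (on this read-out lower numbers stand for stronger inhibition and higher numbers for weaker inhibition), compound 1 (`COc1cc(OC)c(C(=O)/C=C/c2ccccc2)c(OC)c1`) gives 5800 nM. Compound 2 (`COc1cc(OC)c(C(=O)/C=C/c2ccc(Cl)cc2)c(OC)c1`) gives 5700 nM, and compound 3 (`COc1cc(OC)c(C(=O)/C=C/c2ccc(F)cc2)c(OC)c1`) gives 5500 nM. Compound 3 thus stands level with the other two, since all three values lie within the scatter of each other.

The next structure is compound 4 (`COc1cc(OC)c(C(=O)/C=C/c2ccc([N+](=O)[O-])cc2)c(OC)c1`). The change is nitro in place of fluoro on an aromatic carbon, on a six-membered aromatic ring of carbon only, para to a large group.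

Among the measured compounds shown here, three measured steps bear on this change, all made at that same place. Chloro in place of hydrogen gives a 1.0-fold lower number from compound 1 to compound 2 (0.01 log units; within the scatter), fluoro in place of hydrogen gives a 1.1-fold lower number from compound 1 to compound 3 (0.02 log units; within the scatter), and fluoro in place of chloro gives a 1.0-fold lower number from compound 2 to compound 3 (0.02 log units; within the scatter). None of them leaves the scatter. For the measured compounds named here, no measured compound carries a nitro group, however, so these steps are only a limited guide and the range is kept wide.

In this assay, the expected step is a 1.1-fold lower number from compound 3 to compound 4 (0.04 log units; within the scatter), and no change beyond the scatter is expected. For compound 4, the estimated value is 5000 nM, with an expected range from 2000 nM to 11000 nM.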

Compound 4, half-maximal inhibitory concentration: 2600 nM
The estimate for compound 4 lay 1.9-fold (0.28 log units) above the measured number, and the stated range covers the measured number.
By their numbers in this assay, from the lowest: compound 4; then compounds 3, 2 and 1 (each within the scatter of the next).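

In this assay nitro in place of fluoro gives a 2.1-fold lower number from compound 3 to compound 4 (0.33 log units; beyond the scatter) and nitro in place of chloro gives a 2.2-fold lower number from compound 2 to compound 4 (0.34 log units; beyond the scatter) while nitro in place of hydrogen gives a 2.2-fold lower number from compound 1 to compound 4 (0.35 log units; beyond the scatter) on the same aromatic carbon. Among the compounds shown here, with hydrogen, chloro and fluoro alone, the series gave no sign that the group at this carbon, para to a large group, could shift the number beyond the scatter; compound 4 is the first to do so, though only modestly, and it stands apart from each of the other three compounds. Nothing at hand accounts for this difference, so the result stays a plain observation on these four compounds.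

On these data alone, whether the shift is particular to nitro stays open, since a single compound carries it and a nitrile, an amine or a carboxylic acid at the same carbon could show whether other groups separate from hydrogen in the same way. Also open, as far as these compounds go, is whether nitro would give a similar step at another carbon of this ring, or on a core with altered methoxy groups.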